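Swapping the Aryl Group on a Weak Trimethoxybenzoyl Compound

The compounds below may be only part of what the source reports. "The series", "measured", "known", "first", "only" and "open" are said of these compounds alone.

In a functional assay on A549 cells (Homo sapiens) for antiproliferative activity, read by MTT assay, with a stated time of 72 h (a higher number here means a weaker inhibitor, a lower number a stronger inhibitor), compound 1 `COc1ccc(-c2c(C(=O)c3cc(OC)c(OC)c(OC)c3)sc3ccccc23)c(OC)c1` gives 5800 nM. In this assay compound 2 `COc1ccc(-c2c(C(=O)c3cc(OC)c(OC)c(OC)c3)sc3ccccc23)cc1C` gives > 10000 nM, which is a limit of the assay and not a number. Compound 3 `CCOc1ccc(-c2c(C(=O)c3cc(OC)c(OC)c(OC)c3)sc3ccccc23)cc1` has the same atoms joined differently, with 4-ethoxyphenyl in place of 4-methoxy-3-methylphenyl on an aromatic carbon. Among the measured compounds shown here, the one measured step at this place is an at least 1.7-fold higher number from compound 1 to compound 2 (0.23 log units; that floor lies within the scatter). Its size is known only as a floor, so it offers no firm guide to a large change in either direction. Taking that step and the value of compound 1 at 5800 nM as the reason, activity in this assay is expected to remain weak. The expected step is an at least 1.6-fold lower number from compound 2 to compound 3 (0.22 log units; that floor lies within the scatter), with no clear move beyond the scatter anticipated. For compound 3 the estimate is 6000 nM, with an expected range from 1500 nM to 15000 nM.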

Compound 3, half-maximal inhibitory concentration: 3100 nM
The estimate for compound 3 lay 1.9-fold (0.29 log units) above the measured number; the range from low to high includes it.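

Rearranging the same atoms within the aryl group is enough to register in this assay: 4-ethoxyphenyl in place of 4-methoxy-3-methylphenyl gives an at least 3.2-fold lower number from compound 2 to compound 3 (0.50 log units; beyond the scatter), the first step at this position that clears the scatter. Set against the 2,4-dimethoxyphenyl group, however, the 4-ethoxyphenyl group gives a 1.9-fold lower number from compound 1 to compound 3 (0.27 log units; within the scatter), so these two groups cannot be told apart here. The true size of the first step stays unknown, since compound 2 carries a limit of the assay and not a number: the limit of > 10000 nM in this assay, at which 1 of the 3 values shown sits.

The compounds shown leave open whether the difference belongs to the ethoxy chain or to the methyl group on the ring. They also leave open whether a longer chain such as butoxy, or an amine or a carboxylic acid on this aryl ring, would move the number further.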